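A Furan for a Thiophene on a Shared Core

A few compounds are considered here, and "the series" means these few. Any claim that something is new, unique, unknown or untested is made for them only; others in the source may bear on it.

The compounds here share one core and differ only in the ester and in the five-membered aromatic ring attached to the saturated ring carbon. All have been tested in an assay on HeLa cells for displacement of a labelled ligand from adenosine receptor A3 (Homo sapiens), read by radioligand binding, with a stated time of 180 min, tested at 1 uM; a higher number here means more inhibition at the concentration tested (going by the name of the read-out), a lower number less inhibition. Compound 1, `CC1=C(C(=O)OC(C(F)(F)F)C(F)(F)F)C(c2ccoc2)NC(=O)N1`, gives 1%. Compound 2, `CC1=C(C(=O)OC(C)C(F)(F)F)C(c2ccoc2)NC(=O)N1`, gives 12%; 5% (2 entries) across its repeated entries; the spread between them, (the several entries of compound 2 in this assay, 12%; 5% (2 entries)), is a reminder of how much repeated measurements can move. Compound 3, `CC1=C(C(=O)OCC(F)(F)F)C(c2ccsc2)NC(=O)N1`, gives 1%, which stands level with compound 1 at the digits shown, so the two are not distinguished by this assay.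

Compound 4, `CC1=C(C(=O)OCC(F)(F)F)C(c2ccoc2)NC(=O)N1`, has not yet been measured in this assay. It differs from compound 3 by one change: furan-3-yl in place of thiophen-3-yl on a saturated ring carbon. Compound 1 and compound 2 already carry the furan-3-yl group, and both sit low in this assay, so the furan itself has not lifted inhibition in the compounds seen so far. The step from compound 3 to compound 4 is therefore expected to stay within the scatter, as a number 2 percentage points higher from compound 3 to compound 4 (within the scatter). Compound 4 is expected to give about 3%, most likely between 0% and 12%.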

Compound 4, a percentage reported as inhibition, at one concentration (the size of the read-out at that concentration, not a potency): 1%
Beside the measured number, compound 4's estimate is 2 percentage points above it; the measured number falls inside the stated range.
By their numbers in this assay, from the lowest: compounds 1, 3 and 4 (each within the scatter of the next).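

Among these compounds, this is the first comparison in which only the five-membered aromatic ring changes, on a saturated ring carbon next to the ring nitrogen: in this assay, furan-3-yl in place of thiophen-3-yl gives no change at the digits printed from compound 3 to compound 4 (within the scatter). The ester can also change without a visible effect here, since hydrogen in place of trifluoromethyl on a saturated chain carbon bound to an oxygen gives no change at the digits printed from compound 1 to compound 4 (within the scatter). Neither exchange can be read as a real difference, as all three compounds give the same small number and the repeated entries of a related compound show how far such readings can move: the several entries of compound 2 in this assay, 12%; 5% (2 entries)

With every value this close to the bottom of the read-out, the result cannot tell whether the two rings would still match on a compound that inhibits strongly at the concentration tested. It also leaves open whether an amine or a carboxylic acid on the same saturated ring carbon, or a longer chain in the ester, would raise the reading at all.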